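A few compounds are considered here, and "the series" means these few. Any claim that something is new, unique, unknown or untested is made for them only; others in the source may bear on it.

Measured so far:
- compound 1, `CCCCCCCCCCCCCC(=O)N[C@@H](CCC(=O)O)C(=O)Nc1ccn([C@H]2O[C@@H](CO)[C@H](O)[C@H]2O)c(=O)n1`: 0.25
- compound 2, `CCCCCCCCCC(=O)N[C@H](C(=O)Nc1ccn([C@H]2O[C@@H](CO)[C@H](O)[C@H]2O)c(=O)n1)C(C)C`: 0.78

In a physicochemical assay for lipophilicity (a higher number here means a more lipophilic compound, a lower number a more polar compound), compound 1 gives 0.25, the lowest of the two numbers recorded. The nearest is compound 2, which in this assay gives 0.78, a difference that lies beyond the scatter of the measurement; compound 2 differs from compound 1 in more than one place, so only the two values themselves can be compared.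

The next compound is compound 3, `CCCCCCCCCCCCCC(=O)N[C@@H](CCSC)C(=O)Nc1ccn([C@H]2O[C@@H](CO)[C@H](O)[C@H]2O)c(=O)n1`, not yet measured. It keeps the shared core, the sugar and the long acyl chain of compound 1 and differs in a single place: methylsulfanyl in place of carboxy on a saturated chain carbon, three bonds along the chain from an amide-type nitrogen and a carbonyl carbon. Within the data shown here, no step between two measured compounds covers this exchange, so the expectation rests on the position of compound 1 alone.

For compound 3 in this assay an upward step is expected, a number 1.35 log units higher from compound 1 to compound 3 (beyond the scatter), clearly beyond the scatter. The estimated value for compound 3 is 1.6, with a range from 1 to 2.3; the measurement will show where it actually falls.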

Compound 3, partition coefficient: 0.88
Estimate against measurement, compound 3: 0.72 log units above; the measured number lies below the stated range.
By their numbers in this assay, from the lowest: compound 1; then compounds 2 and 3 (each within the scatter of the next).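

In this assay the exchange of carboxy for methylsulfanyl, on a saturated chain carbon, three bonds along the chain from an amide-type nitrogen and a carbonyl carbon, gives a number 0.63 log units higher from compound 1 to compound 3 (beyond the scatter) as a modest step, with the shared core, the sugar and the long acyl chain held constant. Among these compounds, this is the first reading of a change at this position alone, and it shows that this place in the chain registers in this assay, which the earlier pair, differing in more than one place, could not show. The count under the exchange is plain: the leaving carboxy carries a hydrogen-bond donor and a hydrogen-bond acceptor, the entering methylsulfanyl carries only an acceptor, yet no measurement here links that count or anything else to the size of the step.

As far as these compounds go, one exchange at one position gives no trend, and how an amine, a hydroxyl or an amide at the same carbon would read against compound 1 remains open. From the compounds shown here alone, the separate contribution of the acyl chain is also open, since a shorter or longer chain on the core of compound 3 would be needed to isolate it.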